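Swapping a Cyclohexylmethyl for an Amino Group

A few compounds are considered here, and "the series" means these few. Any claim that something is new, unique, unknown or untested is made for them only; others in the source may bear on it.

compound 1 `C/C(=N\OCC(=O)O)c1ccccc1C(=O)O`: < 20%
compound 2 `C/C(=N\OCC(=O)O)c1ccc(CC2CCCCC2)cc1`: < 20%

Of the compounds shown here, two sharing the oxime-ether acetic acid core have been tested in a functional assay on the whole organism for inhibition, with Rattus norvegicus as the target, read by paw edema, with stated times of 1 h and 3 h, at a dose of 50 mg/kg by the oral route; on this read-out lower numbers stand for less inhibition and higher numbers for more inhibition at the one dose given (going by the name of the read-out). Compound 1 gives < 20%, which is a limit of the assay and not a number. In this assay compound 2 gives < 20%, again a limit rather than a number. Among the compounds with values here, compound 2 therefore stands at the floor of what this assay reports, and so does the only other value shown (the limit of < 20% in this assay, at which 2 of the 2 values shown sit). Within the data shown here, no step between measured compounds can be drawn, since the two do not differ in one place.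

The next compound, compound 3 `C/C(=N\OCC(=O)O)c1ccc(N)cc1`, is derived from compound 2 by one change: amino in place of cyclohexylmethyl on an aromatic carbon. With both measured values sitting at the limit, nothing shown points to a step in either direction beyond the scatter. Compound 3 is therefore expected near the same floor, with the estimated step that the limit leaves unreadable from compound 2 to compound 3. The value of compound 3 in this assay is estimated at 15%, between 0% and 35%.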

Compound 3, a percentage reported as inhibition, in the whole organism at one dose (the size of the read-out at that dose, not a potency): 20%
Beside the measured number, compound 3's estimate is 5 percentage points below it; the range from low to high includes it.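

Within the data shown here, at this position, on an aromatic carbon para to a group of 8 heavy atoms, the change to amino gives the first reading that is a number and not a limit: in this assay compound 3 gives 20%. Replacing the cyclohexylmethyl group, with its carbon-only ring, by a single nitrogen group gives a number no lower from compound 2 to compound 3 (the limit leaves the size open). The size of that step cannot be read, and the floor of the read-out still marks most of what is shown: the limit of < 20% in this assay, at which 2 of the 3 values shown sit.

The compounds shown leave open whether amino differs from cyclohexylmethyl by more than the usual scatter. They also leave open what a carboxylic acid, a hydroxyl or a longer carbon chain at this same position would give in this assay.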